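The compounds below may be only part of what the source reports. "The series", "measured", "known", "first", "only" and "open" are said of these compounds alone.

Working notes on the series.

Compound 1 `CC(C)C(C(N)=O)c1ccc(Cl)cc1` carries a primary amide on the shared core. In a functional assay on CHO cells for agonist activity at Free fatty acid receptor 2 (Homo sapiens), read by cAMP accumulation (on this read-out higher numbers stand for larger maximal responses and lower numbers for smaller maximal responses), compound 1 gives < 30%, which is a limit of the assay and not a number. Compound 2 `CC(C)[C@H](C(=O)NC(C)(C)C)c1ccc(Cl)cc1` bears a tert-butyl group on the amide nitrogen. In this assay compound 2 gives < 30%, again a limit and not a number. Compound 2 therefore stands at the lower bound of what this assay reports, with the limit of < 30% in this assay, at which 2 of the 2 values shown sit; nothing separates it from compound 1 on the values at hand.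

Compound 3 `CC(C)[C@H](C(=O)Nc1ncc[nH]1)c1ccc(Cl)cc1` is the next analogue, differing from compound 2 by 1H-imidazol-2-yl in place of tert-butyl on an amide-type nitrogen. Among the compounds with values here, no measured step between two compounds is available to size this change, so the expectation rests on the limit values alone. The step from compound 2 to compound 3 is expected to be a number at least 10 percentage points higher from compound 2 to compound 3 (that floor lies within the scatter) in this assay, with the change at the amide nitrogen considered open in either direction. For compound 3 the expected maximal response in this assay is 40%, in the range 10% to 90%.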

Compound 3, largest response reached (reported as efficacy), in percent of the reference or control that the assay uses: 55%
Beside the measured number, compound 3's estimate is 15 percentage points below it; low and high end bracket the measured number.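

The amide nitrogen is a position where the substituent can lift the response out of the limit region: with 1H-imidazol-2-yl in place of tert-butyl, this assay shows a number at least 25 percentage points higher from compound 2 to compound 3 (beyond the scatter). Within the data shown here, this change gives the series a measured maximal response for the first time, with compound 3 at 55%. The earlier compounds offered no number to work from, since each gave only a limit of the assay: the limit of < 30% in this assay, at which 2 of the 3 values shown sit.

The size of the step is bounded on one side only, and a single change cannot separate the contribution of the aromatic ring from that of its two ring nitrogens. A plain phenyl ring, a 2-pyridyl ring or a 1H-pyrazol-3-yl ring on the same nitrogen would be needed to tell these apart.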